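Trifluoromethoxy in place of trifluoromethyl: working notes

A few compounds are considered here, and "the series" means these few. Any claim that something is new, unique, unknown or untested is made for them only; others in the source may bear on it.

Measured so far in a functional assay on DU-145 cells (Homo sapiens) for antiproliferative activity, read by fluorescence and propidium iodide staining, with a stated time of 96 h; a lower number here means a stronger inhibitor, a higher number a weaker inhibitor
compound 1 `CC(O)(COc1cc(C(C)(C)C)cc(C(C)(C)C)c1)C(=O)Nc1ccc(C#N)c(C(F)(F)F)c1` gives 3150 nM
compound 2 `CC(O)(CS(=O)(=O)c1cccc(C(F)(F)F)c1)C(=O)Nc1cc(C(F)(F)F)cc(C(F)(F)F)c1` gives 11500 nM
compound 3 `CC(O)(CS(=O)(=O)c1ccccc1C(F)(F)F)C(=O)Nc1cc(C(F)(F)F)cc(C(F)(F)F)c1` gives 11000 nM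

Compound 3 at 11000 nM sits at the high end of these three numbers, within the scatter of compound 2, while compound 1 at 3150 nM lies lower by more than the scatter.

Next is compound 4 `CC(O)(CS(=O)(=O)c1ccccc1OC(F)(F)F)C(=O)Nc1cc(C(F)(F)F)cc(C(F)(F)F)c1`, which has trifluoromethoxy in place of trifluoromethyl on an aromatic carbon, ortho to a large group (trifluoromethoxy in place of trifluoromethyl on an aromatic carbon). Within the data shown here, only one measured step touches this group (a 1.0-fold lower number from compound 2 to compound 3 (0.02 log units; within the scatter)), with 2-(trifluoromethyl)phenyl in place of 3-(trifluoromethyl)phenyl on a sulfonyl sulfur, and it stays within the scatter. Among the measured compounds shown here, no measured step exchanges trifluoromethyl for trifluoromethoxy, so this evidence is indirect. No step beyond the scatter is therefore expected in this assay, and neither direction is favoured. The expected step (a 1.1-fold lower number from compound 3 to compound 4 (0.04 log units; within the scatter)) is an estimate that stays within the scatter. Compound 4 is estimated at 10000 nM with an expected range from 5000 nM to 20000 nM in this measurement.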

Compound 4, half-maximal inhibitory concentration: 12900 nM
Compound 4: the middle estimate sits 1.3-fold (0.11 log units) below what was measured, and the stated range covers the measured number.
By their numbers in this assay, from the lowest: compound 1; then compounds 3, 2 and 4 (each within the scatter of the next).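

In this assay, the exchange of trifluoromethyl for trifluoromethoxy on an aromatic carbon, ortho to a large group, now has a direct reading within the scatter (a 1.2-fold higher number from compound 3 to compound 4 (0.07 log units; within the scatter)). The reading across the two changes together also stays within the scatter (a 1.1-fold higher number from compound 2 to compound 4 (0.05 log units; within the scatter)), so compound 2, compound 3 and compound 4 form one group at this position. No measurement is available that bears on the reason for this result.

The compounds shown leave open whether a group of another kind at this place, such as an amine or a carboxylic acid, would give a step beyond the scatter. They also leave open whether the same exchange reads alike on the core of compound 1.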